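From compound 3 to compound 4: working notes

This account rests on a few compounds, and the source may have more. Where it says the series, first, only, none or still open, it means among the compounds named here.

Compound 1 `OC[C@H]1O[C@@H](n2cnc3c(NCc4ccccc4Cl)ncnc32)[C@H](O)[C@@H]1O` gives > 166000 nM in an ADME assay on NIH3T3 cells (Mus musculus) for cytotoxicity, with a stated time of 72 h (on this read-out higher numbers stand for weaker inhibition and lower numbers for stronger inhibition), and this value is a limit of the assay. Compound 2 `COc1ccccc1CNc1ncnc2c1ncn2[C@@H]1O[C@H](CO)[C@@H](O)[C@H]1O` gives 140000 nM in this assay. Compound 3 `COc1ccc(CNc2ncnc3c2ncn3[C@@H]2O[C@H](CO)[C@@H](O)[C@H]2O)c(OC)c1` offers no number to start from, as its entry in this assay reads "not determined" (no result reported). Its standing can therefore be described only through its two neighbours in the series.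

Compound 4 `OC[C@H]1O[C@@H](n2cnc3c(NCc4ccc(F)cc4F)ncnc32)[C@H](O)[C@@H]1O` carries 2,4-difluorophenyl in place of 2,4-dimethoxyphenyl on a saturated chain carbon bound to a nitrogen on an aromatic ring.

Within the data shown here, one measured step bears on this change: an at least 1.1-fold lower number from compound 1 to compound 2 (0.07 log units; that floor lies within the scatter), with methoxy in place of chloro on an aromatic carbon. That step rests on (the limit of > 166000 nM in this assay, at which 1 of the 3 values shown sits), so it gives a floor and no exact size. It is also a single pair, and it exchanges chloro rather than fluoro. Among the measured compounds shown here, with that step as the only guide, no shift beyond the scatter is expected in this assay, and compound 4 should read close to the level of compounds 1 and 2. A report as a limit would be no surprise. The estimated value for compound 4 is 150000 nM, with an expected range from 70000 nM to 320000 nM.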

Compound 4, half-maximal inhibitory concentration: > 166000 nM
Compound 4 was reported as a limit (the forecaster's own chance of this, stated with the estimate: 40%); middle value at least 1.1-fold (0.04 log units) from the limit.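

Among these compounds, with 2,4-difluorophenyl on the saturated chain carbon bound to a nitrogen on an aromatic ring, this assay again returns a limit rather than a number, so two halogen-bearing groups, 2-chlorophenyl and 2,4-difluorophenyl, now stand at a limit, while 2-methoxyphenyl remains the only group here with an exact value. Among the compounds shown here, the one readable step is an at least 1.1-fold higher number from compound 2 to compound 4 (0.07 log units; that floor lies within the scatter); it is a floor, so the exchange of 2-methoxyphenyl for 2,4-difluorophenyl shows no shift beyond the scatter, and its true size remains unknown. The step linking compound 1 and compound 4 cannot be read, and the upper end of the scale now restricts what this series can show: the limit of > 166000 nM in this assay, at which 2 of the 4 values shown sit.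

Compound 3 still has no result, so the direct exchange of 2,4-dimethoxyphenyl for 2,4-difluorophenyl has no size. As far as these compounds go, whether an aromatic ring carrying an amine or a carboxylic acid, or a longer chain at this place, would give an exact number well away from the limit remains open.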